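Ethyl for Methoxycarbonyl: Cytotoxicity Expected to Stay Flat

The compounds below may be only part of what the source reports. "The series", "measured", "known", "first", "only" and "open" are said of these compounds alone.

Compound 3 `COC(=O)c1cccc(NC(=O)C2CCCN(C(=O)c3cc(C(F)(F)F)cc(C(F)(F)F)c3)C2)c1` gives 0% in an ADME assay on PC-3 cells (Homo sapiens) for cytotoxicity, read by WST assay, tested at 100 uM; a higher number here means more inhibition at the concentration tested (going by the name of the read-out), a lower number less inhibition. Compound 1 `O=C(Nc1cccc(Oc2ccccn2)c1)C1CCCN(C(=O)c2cc(C(F)(F)F)cc(C(F)(F)F)c2)C1` gives 0% in this assay, and compound 2 `C=Cc1cccc(C(=O)N2CCCC(C(=O)Nc3ccc(Cl)cc3)C2)c1` gives 0%, so compound 3 sits level with both at the digits shown. Among the compounds with values here, the only measured step that bears on the new change, no change at the digits printed from compound 1 to compound 3 (within the scatter), exchanged one group for another on an aromatic carbon without moving the read-out beyond the scatter. Compound 4 `CCc1cccc(NC(=O)C2CCCN(C(=O)c3cc(C(F)(F)F)cc(C(F)(F)F)c3)C2)c1` differs from compound 3 by ethyl in place of methoxycarbonyl on an aromatic carbon. Within the data shown here, no measured step involves ethyl, so the expectation rests on the flat read-out across the three measured compounds. Compound 4 is therefore expected to show no change beyond the scatter, an expected step of no change at the digits printed from compound 3 to compound 4 (within the scatter). The estimated value of compound 4 is 0%, with a range from -8% to 10%.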

Compound 4, a percentage reported as inhibition, at one concentration (the size of the read-out at that concentration, not a potency): 0%
The estimate for compound 4 equals the measured number at the digits printed, and the stated range covers the measured number.
By their numbers in this assay, from the lowest: compounds 1, 2, 3 and 4 (each within the scatter of the next).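

In this assay the exchange of methoxycarbonyl for ethyl, which has no hydrogen-bond acceptors, gives no change at the digits printed from compound 3 to compound 4 (within the scatter) on this aromatic carbon meta to a large group. Ethyl, with no ring, reads the same against (pyridin-2-yl)oxy, with no change at the digits printed from compound 1 to compound 4 (within the scatter) at that carbon. No measurement shown gives any reason for this flat read-out. Going by these compounds, whether an amine or a carboxylic acid on this carbon would move the read-out away from compound 4 at 0% stays open. So does whether a change elsewhere on the shared core would move it.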